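The source may hold more compounds than are shown below. What is called first, only, known or untested is meant among the compounds shown, and "the series" means these compounds.

Measured compounds:
compound 1 `O=C(O)CC/C=C\CO[C@@H]1C(OCc2ccc(-c3ccccc3)cc2)CC[C@@H]1N1CCCCC1`, 39.8 nM in a functional assay on blood for antagonist activity at thromboxane A2 receptor (Homo sapiens); on this read-out lower numbers stand for tighter binding and higher numbers for weaker binding
compound 2 `CS(=O)(=O)Nc1ccccc1-c1ccc(COC2CC[C@H](N3CCCCCC3)[C@H]2OC/C=C\CCC(=O)O)cc1`, 10 nM in this assay
compound 3 `CS(=O)(=O)Nc1ccccc1-c1ccc(CO[C@H]2CC[C@H](N3CCCCCC3)[C@H]2OC/C=C\CCC(=O)O)cc1`, 6.31 nM in this assay

Compound 2 stands second highest of the three numbers. Its nearest neighbour is compound 3, reached by a 1.6-fold lower number from compound 2 to compound 3 (0.20 log units; within the scatter); the two structures are the same and the difference rests only on (the fact that one of compounds 2 and 3 is drawn with a defined configuration and the other without, at the place where they differ). The furthest is compound 1, whose number is higher and beyond the scatter, but compound 1 differs from compound 2 in two places, so the two values only show that compound 1 is the weaker of the pair.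

Compound 4 `O=C(O)CC/C=C\CO[C@H]1C(OCc2ccc(-c3ccccc3O)cc2)CC[C@@H]1N1CCCCCC1` is not yet measured. Against compound 2 it carries hydroxy in place of methanesulfonamido on an aromatic carbon. For the measured compounds named here, no measured step touches this part of the molecule: the only step on record, from compound 2 to compound 3, is stereochemical and within the scatter, so it gives no guide. Compound 1, which lacks any group at this position but also carries a smaller saturated ring, sits higher than compound 2; what share of that gap belongs to the aromatic substituent cannot be separated out.

Compound 4 is therefore expected to give a number somewhat higher than compound 2, estimated as a 2.2-fold higher number from compound 2 to compound 4 (0.34 log units; beyond the scatter), with an estimate of 22 nM and a range of 7 nM to 70 nM.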

Compound 4, dissociation constant: 15.9 nM
For compound 4 the middle estimate is 1.4-fold (0.14 log units) above the measured one; measured number inside the range.
By their numbers in this assay, from the lowest: compounds 3, 2 and 4 (each within the scatter of the next, the first and the last beyond it); then compound 1.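

Exchanging methanesulfonamido for hydroxy on this aromatic carbon in this assay gives a 1.6-fold higher number from compound 2 to compound 4 (0.20 log units; within the scatter). This is the only reading at this position with the saturated ring and the rest of the molecule held as listed for the pair, and it shows that the position tolerates a large change in the group: the methanesulfonamido group is not required for a value within the scatter of compound 2, and hydroxy, which has no sulfur or nitrogen but keeps the count of one hydrogen-bond donor, serves equally well here. Nothing on record bears on why the two groups read alike, and the shared donor count remains only a count.

Still open, going by these compounds, is whether that tolerance extends to groups with no hydrogen-bond donor, such as methoxy, or to other groups on the same aromatic carbon, such as an amine or a carboxylic acid. Also open, on these data alone, is what the bare phenyl gives with the same saturated ring, since that would show whether any group is needed at this place at all.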